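Aryl change on the chain of compound 1

The compounds below may be only part of what the source reports. "The series", "measured", "known", "first", "only" and "open" are said of these compounds alone.

In a functional assay on DU-145 cells (Homo sapiens) for inhibition, read by trypan blue exclusion, with a stated time of 96 h (on this read-out higher numbers stand for weaker inhibition of growth and lower numbers for stronger inhibition of growth), compound 1 `Cc1ccc(S(=O)(=O)/C(=C/c2ccc(O)c([N+](=O)[O-])c2)C(=O)c2ccc(Cl)cc2)cc1` gives 25000 nM, the highest of the three numbers recorded. Compound 2 `O=C(/C(=C\c1ccc(O)c([N+](=O)[O-])c1)SCc1ccc(Cl)cc1)c1ccc(Cl)cc1` gives 10000 nM and compound 3 `O=C(/C(=C\c1ccc(O)c([N+](=O)[O-])c1)S(=O)(=O)Cc1ccccc1Cl)c1ccc(Cl)cc1` gives 10000 nM. The steps of a 2.5-fold lower number from compound 1 to compound 2 (0.40 log units; beyond the scatter) and a 2.5-fold lower number from compound 1 to compound 3 (0.40 log units; beyond the scatter) both alter the sulfonyl side of the shared core; neither touches the group on a double-bonded chain carbon bound to a double-bonded chain carbon. Compound 4 `Cc1ccc(S(=O)(=O)/C(=C/c2ccc(N(C)C)cc2)C(=O)c2ccc(Cl)cc2)cc1` differs from compound 1 exactly there: 4-(dimethylamino)phenyl in place of 4-hydroxy-3-nitrophenyl on a double-bonded chain carbon bound to a double-bonded chain carbon. Going by the values given here, no measured step bears on this change, so its size and direction cannot be read from the series; the working expectation is a step within the scatter, no change at the digits printed from compound 1 to compound 4 (within the scatter). Compound 4 is therefore estimated at 25000 nM, with a loose range from 6000 nM to 100000 nM.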

Compound 4, concentration for 50% growth inhibition: > 100000 nM
Compound 4: a limit, no number (the forecaster's own chance of this, stated with the estimate: 25%); at least 4.0-fold (0.60 log units) between middle value and limit.
By their numbers in this assay, from the lowest: compounds 2 and 3 (each within the scatter of the next); then compound 1. At a limit, above all of these: compound 4.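

In this assay, 4-(dimethylamino)phenyl in place of 4-hydroxy-3-nitrophenyl gives an at least 4.0-fold higher number from compound 1 to compound 4 (0.60 log units; beyond the scatter). This is the first step shown at this position, and unlike the two steps on the sulfonyl side, it goes toward weaker inhibition of growth. The value of compound 4 is a limit, not a number: > 100000 nM.

The step replaces the hydroxy and nitro groups together, so their separate contributions cannot be read. Going by these compounds, how a 4-hydroxyphenyl, a 3-nitrophenyl or a 4-aminophenyl group would read at this position remains open.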